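Adding an isopentyl chain to a primary amide

A few compounds are considered here, and "the series" means these few. Any claim that something is new, unique, unknown or untested is made for them only; others in the source may bear on it.

Values measured in a physicochemical assay for solubility (a lower number here means a less soluble compound, a higher number a more soluble compound), are these:
- compound 1 `CNC(=O)c1cc(C(=O)NC)c(=O)n(Cc2ccccc2)c1` gives >= 118 ug/mL as a limit of the assay, not a number
- compound 2 `CNC(=O)c1cc(C(=O)NCC(C)C)cn(Cc2ccccc2)c1=O` gives 43 ug/mL
- compound 3 `CNC(=O)c1cc(C(N)=O)cn(Cc2ccccc2)c1=O` gives 71 ug/mL

Compound 3 and compound 2 lie within the usual scatter of each other, so neither can be ranked above the other. The reading for compound 1 is only a limit.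

Compound 4 `CNC(=O)c1cc(C(=O)NCCC(C)C)cn(Cc2ccccc2)c1=O` has isopentyl in place of hydrogen on an amide-type nitrogen of compound 3 (isopentyl in place of hydrogen on an amide-type nitrogen). The closest measured step is a similar swap in the opposite direction, hydrogen in place of isobutyl on an amide-type nitrogen (a 1.7-fold higher number from compound 2 to compound 3 (0.22 log units; within the scatter)), and it stays within the scatter. A second step, with isopropyl in place of hydrogen on a saturated chain carbon bound to an amide-type nitrogen (an at least 2.7-fold lower number from compound 1 to compound 2 (0.43 log units; beyond the scatter)), goes beyond the scatter toward a lower number. The third step, with hydrogen in place of methyl on an amide-type nitrogen (an at least 1.6-fold lower number from compound 1 to compound 3 (0.22 log units; that floor lies within the scatter)), has a floor within the scatter and says little. Compound 2 therefore suggests a modest fall, and the expected step is a 2.4-fold lower number from compound 3 to compound 4 (0.37 log units; beyond the scatter) in the same direction. In this assay the estimate for compound 4 is 30 ug/mL with an expected range of 11 ug/mL to 70 ug/mL and that range remains only an expectation.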

Compound 4, solubility: 10 ug/mL
Compound 4: the middle estimate sits 3.0-fold (0.48 log units) above what was measured; the measured number lies below the stated range.
By their numbers in this assay, from the lowest: compound 4; then compounds 2 and 3 (each within the scatter of the next). At a limit, above all of these: compound 1.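

In this assay, putting isopentyl in place of hydrogen on this amide-type nitrogen gives a 7.1-fold lower number from compound 3 to compound 4 (0.85 log units; beyond the scatter), whereas the earlier swap of hydrogen in place of isobutyl at the same place gave only a 1.7-fold higher number from compound 2 to compound 3 (0.22 log units; within the scatter). So a chain here can move the number beyond the scatter, and the isopentyl chain also parts clearly from the shorter isobutyl chain, with a 4.3-fold lower number from compound 2 to compound 4 (0.63 log units; beyond the scatter). The widest gap shown is an at least 11-fold lower number from compound 1 to compound 4 (1.07 log units; beyond the scatter), and its size is only a floor, set by a limit of the assay: the limit of >= 118 ug/mL in this assay, at which 1 of the 4 values shown sits.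

Going by these compounds, whether the number keeps falling with a longer chain, such as hexyl, or whether a chain ending in an amine or a carboxylic acid would hold it up, stays open. On these data alone, how a ring on this nitrogen, such as cyclohexyl or phenyl, would read in this assay also stays open.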